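Benzoyl for fluoro on the oxindole-free core: notes

The compounds below may be only part of what the source reports. "The series", "measured", "known", "first", "only" and "open" are said of these compounds alone.

The series shares the core of compound 1 `O=Cc1cccc(OCc2cn(Cc3ccccc3)nn2)c1` and is tested in a functional assay on HeLa cells (Homo sapiens) for inhibition, read by MTT assay, with a stated time of 48 h; a lower number here means a stronger inhibitor, a higher number a weaker inhibitor. In this assay compound 1 gives > 50000 nM, which is a limit of the assay rather than a number. Compound 2 `O=C1Nc2ccc(Br)cc2/C1=C/c1cccc(OCc2cn(Cc3ccccc3)nn2)c1` in this assay gives > 50000 nM, again a limit. Compound 3 `O=C1Nc2ccc(F)cc2/C1=C\c1cccc(OCc2cn(Cc3ccccc3)nn2)c1` in this assay gives > 50000 nM, also a limit. Compound 3 therefore stands at the limit of > 50000 nM in this assay, at which 3 of the 3 values shown sit, with no ordering possible among the three.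

Compound 4 `O=C1Nc2ccc(C(=O)c3ccccc3)cc2/C1=C\c1cccc(OCc2cn(Cc3ccccc3)nn2)c1` differs from compound 3 by benzoyl in place of fluoro on an aromatic carbon. Within the data shown here, no step between measured compounds is available. Compound 4 is expected at 30000 nM, within 5000 nM to 100000 nM. The estimated step of an at least 1.6-fold lower number from compound 3 to compound 4 (0.22 log units; that floor lies within the scatter) is expected to be small, with a limit value remaining the more likely outcome.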

Compound 4, half-maximal inhibitory concentration: > 50000 nM
Compound 4: only a limit was reported (the forecaster's own chance of this, stated with the estimate: 55%); middle value at least 1.6-fold (0.22 log units) away from the limit.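

Compound 3 and compound 4 both give only a limit, so no step can be read for benzoyl in place of fluoro: the limit of > 50000 nM in this assay, at which 4 of the 4 values shown sit. The compounds shown leave open whether any change to the shared core gives a real number rather than a limit.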